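A few compounds are considered here, and "the series" means these few. Any claim that something is new, unique, unknown or untested is made for them only; others in the source may bear on it.

Measured in an assay on isolated protein for inhibition of Indoleamine 2,3-dioxygenase 1 (Homo sapiens), with a stated time of 30 min; on this read-out lower numbers stand for stronger inhibition and higher numbers for weaker inhibition: compound 1 `N#Cc1ccc(NC(=O)NCc2cnc3scc(-c4ccc(Br)cc4)n23)cc1` gives 77 nM. Compound 2 `CCOC(=O)c1cnc2scc(-c3cccc(C)c3)n12` reaches only a limit of the assay, > 100000 nM. Compound 3 `CCOC(=O)c1cnc2scc(Cc3ccccc3)n12` likewise reaches only a limit, > 100000 nM.

Compound 2 thus stands at the weak end of what this assay reports, without a number, on (the limit of > 100000 nM in this assay, at which 2 of the 3 values shown sit). The change to compound 4 `CCOC(=O)c1cnc2scc(-c3ccccc3)n12` is hydrogen in place of methyl on an aromatic carbon, the methyl leaving a six-membered aromatic ring of carbon only and a hydrogen taking its place. Within the data shown here, no measured step between compounds is available here, so the expectation rests on compound 2 alone: no shift beyond the scatter, and most probably another limit, because compound 2 already sits at the limit of > 100000 nM in this assay, at which 2 of the 3 values shown sit. Compound 4 is expected at about 100000 nM, between 30000 nM and 300000 nM, an expected step of a number no higher from compound 2 to compound 4 (the limit leaves the size open).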

Compound 4, half-maximal inhibitory concentration: > 100000 nM
Compound 4: no number, only a limit (the forecaster's own chance of this, stated with the estimate: 90%); the middle value lies on the limit itself.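

Among these compounds, compound 2 and compound 4 both reach only a limit of the assay, so no step between them can be read. The compounds shown leave open whether hydrogen in place of methyl changes inhibition at all.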